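The source may hold more compounds than are shown below. What is called first, only, known or untested is meant among the compounds shown, and "the series" means these compounds.

Compound 2, with structure `CCCS(=O)(=O)Nc1ccc(F)c(C(=O)c2n[nH]c3ncc(-c4ccc(O)cc4)cc23)c1F`, is measured in an assay for binding affinity to dual specificity mitogen-activated protein kinase kinase 4 (Homo sapiens), read by KINOMEscan, tested at 100 nM (on this read-out lower numbers stand for a stronger effect and higher numbers for a weaker effect at the one concentration tested), where it gives 0.75%. Among the compounds with values here, its only neighbour among the measured compounds is compound 1, with structure `CCCS(=O)(=O)Nc1ccc(F)c(C(=O)c2n[nH]c3ncc(-c4cccc(O)c4)cc23)c1F`, which in this assay gives 2.2%. Within the data shown here, the step of a number 1.5 percentage points lower from compound 1 to compound 2 (within the scatter) is the sole measured step, and it lies within the scatter, so on the numbers at hand compound 2 stands alongside compound 1 rather than apart from it.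

Compound 3 has structure `CCCS(=O)(=O)Nc1ccc(F)c(C(=O)c2n[nH]c3ncc(-c4ccc(Cl)c(C(F)(F)F)c4)cc23)c1F`. The change from compound 2 to compound 3 is 4-chloro-3-(trifluoromethyl)phenyl in place of 4-hydroxyphenyl on an aromatic carbon. Among the measured compounds shown here, the one measured step concerns a hydroxyphenyl group moved from one position to another, and it does not touch the kind of change made here, where the hydroxyl group goes away entirely and two halogen-bearing substituents come in. For the measured compounds named here, no measured step therefore bears directly on the new compound, and the direction of the change cannot be read from the data.

With that caution, the value of compound 3 is expected to be 6%, with a range from 0.5% to 45%, which means an expected step of a number 5.3 percentage points higher from compound 2 to compound 3 (within the scatter) in this assay.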

Compound 3, a percentage reported as activity, at one concentration (the size of the read-out at that concentration, not a potency): 15%
Beside the measured number, compound 3's estimate is 9 percentage points below it; the range from low to high includes it.
By their numbers in this assay, from the lowest: compounds 2 and 1 (each within the scatter of the next); then compound 3.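

Within the data shown here, the two hydroxyphenyl groups could not be told apart in this assay, so the earlier compounds left open whether this position responds to its substituent at all. Replacing either group with 4-chloro-3-(trifluoromethyl)phenyl answers that: the result is a number 14.3 percentage points higher from compound 2 to compound 3 (beyond the scatter) and a number 12.8 percentage points higher from compound 1 to compound 3 (beyond the scatter), so what sits at this position does register in the read-out, although both steps are modest. The data offer no measured explanation for this shift, and the swap removes the hydroxyl while adding both chlorine and trifluoromethyl, so the steps belong to the whole exchange and not to any one of these parts.

On these data alone, how much each part contributes stays open, and a plain phenyl, 4-chlorophenyl or 3-(trifluoromethyl)phenyl group at the same place would help separate them. It is also unknown whether a different group in place of the hydroxyl, such as an amine or a carboxylic acid on the phenyl ring, would stay with compound 2 and compound 1 or move towards compound 3.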